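The source may report more compounds than this note shows. Statements on the series, on what has been measured and on what is new or still open speak of the compounds shown alone.

Compound 1 `C=COC(=O)[C@H](CC(C)C)NC(=O)[C@H](CC(C)C)NC(=O)[C@H](CC(C)C)NC(=O)CCCCNC(=O)OCc1ccccc1`, compound 2 `C=COC(=O)[C@H](CC(C)C)NC(=O)[C@H](CC(C)C)NC(=O)[C@H](CC(C)C)NC(=O)CCCCCNC(=O)OCc1ccccc1` and compound 3 `C=COC(=O)[C@H](CC(C)C)NC(=O)[C@H](CO)NC(=O)[C@@H](NC(=O)CCCCCNC(=O)OCc1ccccc1)C(C)C` were examined in an ADME assay on a cell-free system (plasma, Homo sapiens) for metabolic stability, with Plasma (Rattus norvegicus) as the target; on this read-out lower numbers stand for a shorter-lived compound and higher numbers for a longer-lived compound. In this assay compound 1 returns only a limit of the measurement, > 6 h. Compound 2 likewise gives a limit, > 6 h. For compound 3 the read-out is again a limit, > 6 h. The two limits leave the step from compound 1 to compound 2 unreadable a step that the two limits leave unreadable from compound 1 to compound 2; the change made there is ((benzyloxycarbonyl)amino)methyl in place of (benzyloxycarbonyl)amino on a saturated chain carbon, four bonds along the chain from a carbonyl carbon. The difference between the core of compound 1 and the core of compound 3 is not broken down here. Compound 4 `C=COC(=O)[C@H](CC(C)C)NC(=O)[C@H](CO)NC(=O)[C@@H](NC(=O)CCCCCCNC(=O)OCc1ccccc1)C(C)C`, still to be measured in this assay, carries the same kind of change relative to compound 3, (((benzyloxycarbonyl)amino)methyl in place of (benzyloxycarbonyl)amino on a saturated chain carbon, five bonds along the chain from a carbonyl carbon), the place differing in that it lies five bonds rather than four bonds along the chain from a carbonyl carbon. Among the measured compounds shown here, since every value so far sits at the limit (the limit of > 6 h in this assay, at which 3 of the 3 values shown sit), the step from compound 3 to compound 4 is expected to be small a step that the limit leaves unreadable from compound 3 to compound 4. Compound 4 is estimated at 9 h, probably between 4 h and 24 h.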

Compound 4, half-life: > 6 h
Compound 4 was reported as a limit; the forecaster's own chance of this, stated with the estimate: 85%; the middle value does not contradict the limit.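

Among the compounds shown here, compound 3 and compound 4 are both reported only as limits in this assay, and no step between them can be read. The compounds shown leave open what half-life any of them actually has, and whether the change from (benzyloxycarbonyl)amino to ((benzyloxycarbonyl)amino)methyl alters it: the limit of > 6 h in this assay, at which 4 of the 4 values shown sit.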